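The source may report more compounds than this note shows. Statements on the series, on what has been measured and on what is new or still open speak of the compounds shown alone.

In a functional assay (aorta) with Oryctolagus cuniculus as the target (on this read-out higher numbers stand for weaker binding and lower numbers for tighter binding), compound 1 `CCc1ccc(OCCCN2CCC(C(c3ccc(F)cc3)c3ccc(F)cc3)CC2)c(OC)c1` gives 2.51 nM, compound 2 `COC(=O)c1ccc(OCCCN2CCC(C(c3ccc(F)cc3)c3ccc(F)cc3)CC2)c(OC)c1` gives 1.26 nM and compound 3 `CC(=O)c1ccc(OCCCN2CCC(C(c3ccc(F)cc3)c3ccc(F)cc3)CC2)cc1` gives 2.51 nM. Compound 3 is thus level with compound 1, and all three lie within the scatter of one another. Compound 4 `N#Cc1ccc(OCCCN2CCC(C(c3ccc(F)cc3)c3ccc(F)cc3)CC2)cc1` carries cyano in place of acetyl on an aromatic carbon, para to a large group (cyano in place of acetyl on an aromatic carbon). For the measured compounds named here, no measured step makes this exact exchange. The closest evidence is a 2.0-fold lower number from compound 1 to compound 2 (0.30 log units; within the scatter), with no change at the digits printed from compound 1 to compound 3 (within the scatter) and a 2.0-fold higher number from compound 2 to compound 3 (0.30 log units; within the scatter), so every shown step stays small. The expected step is a 1.3-fold higher number from compound 3 to compound 4 (0.11 log units; within the scatter), with none beyond the scatter anticipated in this assay. Compound 4 is estimated at 3.2 nM, with an expected range of 1 nM to 10 nM.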

Compound 4, dissociation constant: 5.01 nM
Compound 4: the middle estimate sits 1.6-fold (0.19 log units) below what was measured; low and high end bracket the measured number.
By their numbers in this assay, from the lowest: compounds 2, 1, 3 and 4 (each within the scatter of the next, the first and the last beyond it).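

In this assay, cyano in place of acetyl on this aromatic carbon, para to a large group, gives a 2.0-fold higher number from compound 3 to compound 4 (0.30 log units; within the scatter), and a 2.0-fold higher number from compound 1 to compound 4 (0.30 log units; within the scatter) also stays inside the scatter. The only step among these beyond the scatter is modest, a 4.0-fold higher number from compound 2 to compound 4 (0.60 log units; beyond the scatter), and it exchanges the whole 2-methoxy-4-(methoxycarbonyl)phenyl group, so it cannot be credited to one substituent. Nothing available accounts for these steps. Open, from the compounds shown here alone, is whether an amine, a carboxylic acid or a primary amide on this carbon would shift the number beyond the scatter.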